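From bromo to methyl at one ring position

The compounds below may be only part of what the source reports. "The series", "measured", "known", "first", "only" and "open" are said of these compounds alone.

Compound 1 `COc1cc(C(=O)/C=C/c2cc(O)ccc2O)cc(OC)c1OC`: > 100000 nM, a limit of the assay and not a number
Compound 2 `COc1cc(C(=O)/C=C/c2ccc(F)cc2)cc(OC)c1OC`: 22000 nM
Compound 3 `COc1cc(C(=O)/C=C/c2ccc(Br)cc2)cc(OC)c1OC`: 80000 nM

These values come from a functional assay on HepG2 cells (Homo sapiens) for inhibition, read by MTT assay, with a stated time of 48 h; a higher number here means a weaker inhibitor, a lower number a stronger inhibitor. Among the two true numbers, compound 3 holds the higher one, so it is the weaker inhibitor of that pair. Compound 4 `COc1cc(C(=O)/C=C/c2ccc(C)cc2)cc(OC)c1OC` keeps the shared core and differs from compound 3 by one change: methyl in place of bromo on an aromatic carbon.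

One measured step changes a group at this same place: a 3.6-fold higher number from compound 2 to compound 3 (0.56 log units; beyond the scatter). It shows that the group here can move the number beyond the scatter, but a single step gives no rule for methyl. A modest shift is therefore possible, and the direction is uncertain. Since compound 2 reads lower at 22000 nM, a slight lean towards a lower number is expected. The estimated change is a 1.9-fold lower number from compound 3 to compound 4 (0.28 log units; within the scatter), which is no larger than the scatter. For compound 4 the expected value is 42000 nM. The estimated range for compound 4 runs from 14000 nM to 100000 nM.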

Compound 4, half-maximal inhibitory concentration: 52000 nM
The estimate for compound 4 lay 1.2-fold (0.09 log units) below the measured number; low and high end bracket the measured number.
By their numbers in this assay, from the lowest: compound 2; then compounds 4 and 3 (each within the scatter of the next). At a limit, above all of these: compound 1.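

Methyl in place of bromo on an aromatic carbon, para to a large group, gives a 1.5-fold lower number from compound 3 to compound 4 (0.19 log units; within the scatter) and so these two groups, each of one heavy atom, cannot be told apart by this read-out. Fluoro stands apart from methyl as well as from bromo: the new step is a 2.4-fold higher number from compound 2 to compound 4 (0.37 log units; beyond the scatter) and it sits alongside the earlier 3.6-fold higher number from compound 2 to compound 3 (0.56 log units; beyond the scatter) at this same position. Among the three compounds with a single group at this position, then, only compound 2 separates from the others. With 4-methylphenyl in place of 2,5-dihydroxyphenyl the data give an at least 1.9-fold lower number from compound 1 to compound 4 (0.28 log units; that floor lies within the scatter) and this is only a floor. Compound 1 stands at a limit and not at a number: the limit of > 100000 nM in this assay, at which 1 of the 4 values shown sits.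

The compounds shown leave open whether the lower number belongs to fluoro alone or would also appear with another group here, such as chloro or an amine. They also do not say why fluoro differs from bromo and methyl.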